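Phenoxy for phenyl: an unmeasured step on the quinoline side

The compounds below may be only part of what the source reports. "The series", "measured", "known", "first", "only" and "open" are said of these compounds alone.

The measured compounds and their values in a physicochemical assay for solubility, with a stated time of 18 h, at pH 7.4; a higher number here means a more soluble compound, a lower number a less soluble compound:
- compound 1, `COc1ccc(F)cc1CNCCCNc1ccnc2cc(CCC(C)C)ccc12`, 4200 nM
- compound 2, `COc1ccc(F)cc1CNCCCNc1ccnc2cc(Cc3ccc(C#N)cc3)ccc12`, 4200 nM
- compound 3, `COc1ccc(F)cc1CNCCCNc1ccnc2cc(-c3ccccc3)ccc12`, 32000 nM

Compound 3 gives the highest of the three numbers. The two steps that reach it are a 7.6-fold higher number from compound 1 to compound 3 (0.88 log units; beyond the scatter) and a 7.6-fold higher number from compound 2 to compound 3 (0.88 log units; beyond the scatter), both beyond the scatter, so compound 3 stands clearly above the other two. Compound 1 and compound 2, by contrast, differ by no change at the digits printed from compound 1 to compound 2 (within the scatter), and no order can be read between them.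

Compound 4, `COc1ccc(F)cc1CNCCCNc1ccnc2cc(Oc3ccccc3)ccc12`, differs from compound 3 in one place: phenoxy in place of phenyl on an aromatic carbon. For the measured compounds named here, none of the measured steps exchanges a direct aryl attachment for one carried through an oxygen; the two steps that reach compound 3 both replace a saturated chain by an aromatic ring, which is a different kind of change. The step to compound 4 keeps the aromatic ring and only inserts the oxygen, so in this assay compound 4 is expected to stay close to compound 3, with a step of a 1.3-fold higher number from compound 3 to compound 4 (0.10 log units; within the scatter) that is not expected to exceed the scatter. The estimate for compound 4 in this assay is 40000 nM, within a range of 15000 nM to 100000 nM.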

Compound 4, solubility: 14500 nM
Estimate against measurement, compound 4: 2.8-fold (0.44 log units) above; the whole stated range lies above it.
By their numbers in this assay, from the lowest: compounds 1 and 2 (each within the scatter of the next); then compound 4; then compound 3.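

In this assay, this position responds to a change as small as one linking oxygen, with a 2.2-fold lower number from compound 3 to compound 4 (0.34 log units; beyond the scatter) and a phenyl ring present on both sides of the step, whereas each earlier step to compound 3 exchanged a saturated chain or a substituted benzyl group for the ring. Compound 4 keeps a clear lead over the two lower compounds, with a 3.5-fold higher number from compound 1 to compound 4 (0.54 log units; beyond the scatter) and a 3.5-fold higher number from compound 2 to compound 4 (0.54 log units; beyond the scatter) in this assay, so the phenoxy compound takes a middle place in the series rather than falling back to their level. Compound 2 also carries an aromatic ring at this position and stays in the lower pair, so the presence of a ring does not by itself set the number, and no measurement is available to explain any of these differences.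

On these data alone, it remains open whether the step to compound 4 is specific to oxygen, which a phenylthio group or an unsubstituted benzyl group at the same position could test. As far as these compounds go, it is also open how a nitrile or a fluorine on the phenoxy ring would shift the number, and whether an anilino link, with nitrogen in place of the oxygen, would resemble compound 3 or compound 4.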